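The source may hold more compounds than are shown below. What is called first, only, known or untested is meant among the compounds shown, and "the series" means these compounds.

Measured set in an assay on Sf9 cells for inhibition of protein deacetylase HDAC6 (Homo sapiens), read by fluorescence, with a stated time of 40 min, tested at 100 nM; on this read-out lower numbers stand for less inhibition and higher numbers for more inhibition at the one concentration tested (going by the name of the read-out):
compound 1 `COc1ccc(-c2nc(CNc3ccc(C(=O)NO)cc3)n(-c3ccccc3)n2)cc1` gives 77.6%
compound 2 `O=C(NO)c1ccc(NCc2nc(-c3ccccc3)nn2-c2ccc(Br)cc2)cc1` gives 65.9%
compound 3 `O=C(NO)c1ccc(NCc2nc(-c3ccccc3)nn2-c2ccc(F)cc2)cc1` gives 67.6%

Compound 1 stands highest of the three numbers. Its nearest neighbour is compound 3, whose number is lower but within the scatter; the furthest is compound 2, whose number is lower and beyond the scatter. For the measured compounds named here, the only step measured between two compounds that differ in one place is a number 1.7 percentage points higher from compound 2 to compound 3 (within the scatter), a halogen exchange that leaves both numbers close to each other.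

The step from compound 1 to compound 4 `O=C(NO)c1ccc(NCc2nc(-c3ccncc3)nn2-c2ccccc2)cc1` is a different kind of change: pyridin-4-yl in place of 4-methoxyphenyl on an aromatic carbon. Going by the values given here, no measured step touches this group, so the halogen exchange from compound 2 to compound 3 does not bear on it, and the measured set gives no direct guide to the size or direction of the step. With nothing to go on beyond the general level of the series, the working assumption is a change in this assay that stays near the range already seen, with a modest downward lean given that compound 1 sits at the top of the measured spread.

Compound 4 is therefore expected to give about 70%, between 52% and 86%, which means an expected step of a number 7.6 percentage points lower from compound 1 to compound 4 (within the scatter).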

Compound 4, a percentage reported as inhibition, at one concentration (the size of the read-out at that concentration, not a potency): 30.8%
Compound 4: middle estimate off by 39.2 percentage points, on the high side; the measured number lies below the stated range.
By their numbers in this assay, from the lowest: compound 4; then compounds 2, 3 and 1 (each within the scatter of the next, the first and the last beyond it).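

In this assay, the aromatic carbon of the five-membered aromatic ring with 3 nitrogen proves sensitive to the group it carries: pyridin-4-yl in place of 4-methoxyphenyl gives a number 46.8 percentage points lower from compound 1 to compound 4 (beyond the scatter), a large step beyond the scatter. The only earlier step, the fluoro for bromo exchange elsewhere in the molecule, gave a number 1.7 percentage points higher from compound 2 to compound 3 (within the scatter), so the series had not yet shown a single change of this size, and the drop appears even though the two groups match in hydrogen-bond donors, hydrogen-bond acceptors and net charge. Nothing measured for these compounds gives a reason for the step.

Still open, on these data alone, is which part of the exchange carries the step, the ring nitrogen of pyridin-4-yl or the missing methoxy group, and a pyridin-3-yl, a 4-hydroxyphenyl or a 4-ethoxyphenyl on the same carbon would help separate the two. Also open, as far as these compounds go, is whether the same exchange costs as much in this assay when the phenyl on the ring nitrogen carries a bromo or fluoro group.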